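The source may hold more compounds than are shown below. What is called first, only, known or untested is meant among the compounds shown, and "the series" means these compounds.

Measured in a functional assay on the whole organism for agonist activity, with Mus musculus as the target; on this read-out higher numbers stand for an effect only at larger amounts of compound and lower numbers for an effect already at smaller amounts:
- Compound 1 `CC1CCC(=O)N1CC#CCN(C)C`: 3.7 mg/kg
- Compound 2 `CC(=O)NCC#CCn1ccnc1`: > 100 mg/kg

Of these two, only compound 1 gives a real number, 3.7 mg/kg. The entry for compound 2, > 100 mg/kg, is a limit of this assay and not a number. Its true position is therefore unknown.

Compound 3 `CC(=O)NCC#CCn1cncc1C` keeps the structure of compound 2 except at one place: methyl in place of hydrogen on an aromatic carbon. This puts methyl in place of hydrogen on an aromatic carbon. For the measured compounds named here, no measured pair of compounds shows what this change does, so any forecast is uncertain, and compound 3 may also end at a limit. In this assay the expected step is small, toward smaller doses if there is any change at all: an at least 1.1-fold lower number from compound 2 to compound 3 (0.04 log units; that floor lies within the scatter). For compound 3 the estimated dose is 90 mg/kg, with an expected range from 30 mg/kg to 250 mg/kg.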

Compound 3, dose for half-maximal effect: 66 mg/kg
Compound 3: the middle estimate sits 1.4-fold (0.13 log units) above what was measured, and the stated range covers the measured number.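

In this assay compound 3 gives 66 mg/kg, so with methyl in place of hydrogen on this aromatic carbon, next to the ring atom that bears a group of 8 heavy atoms, the read-out is a real number. The change amounts to an at least 1.5-fold lower number from compound 2 to compound 3 (0.18 log units; that floor lies within the scatter), so this methyl may have a larger effect or no real effect at all. The true size of the step cannot be read because compound 2 has only a limit and not a number: the limit of > 100 mg/kg in this assay, at which 1 of the 3 values shown sits.

The compounds shown leave open whether an ethyl group or a chlorine atom on this same carbon would shift the dose further. For the compounds shown here, they also leave open whether methyl would act the same way on another core, as this change appears in only one pair of compounds.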